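The source may report more compounds than this note shows. Statements on the series, on what has been measured and on what is new or still open speak of the compounds shown alone.

Measured compounds and their values in a functional assay on CHO cells for agonist activity at Free fatty acid receptor 1 (Homo sapiens), read by calcium flux; on this read-out lower numbers stand for an effect already at smaller amounts and higher numbers for an effect only at larger amounts of compound:
compound 1 `Cc1cccc(C)c1-c1cccc(COc2ccc(CCC(=O)O)cc2)c1`: 6.7 nM
compound 2 `Cc1cc(OCc2cccc(-c3c(C)cccc3C)c2)ncc1CCC(=O)O`: 9.3 nM
compound 3 `Cc1cccc(C)c1-c1cccc(COc2ccc(CC(C)C(=O)O)cn2)c1`: 65 nM

All three share a core with two aromatic rings joined directly and a third ring linked through an oxygen; they differ in the acid-bearing chain and in the ring that carries it. Among them, compound 3 stands at the highest number, that is, it needs the most compound for a half-maximal effect; the step from it to compound 2 and the step from it to compound 1 both lie beyond the usual scatter, so compound 3 is the weakest of the three in this assay.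

Compound 4 `Cc1cccc(C)c1-c1cccc(COc2ccc(C(F)CC(=O)O)cn2)c1` has not yet been measured. It differs from compound 3 in one place: 2-carboxy-1-fluoroethyl in place of 2-carboxypropyl on an aromatic carbon. The branching methyl on the chain is gone, and a fluorine now sits on the chain carbon that joins the ring. Going by the values given here, no measured pair shows exactly this kind of change, so the expectation rests on where compound 3 stands relative to the others. The number for compound 4 is expected to come down, with a step of a 2.6-fold lower number from compound 3 to compound 4 (0.41 log units; beyond the scatter) from compound 3. Compound 4 is therefore estimated at 25 nM, likely within 8 nM to 80 nM.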

Compound 4, half-maximal effective concentration: 18 nM
Estimate against measurement, compound 4: 1.4-fold (0.14 log units) above; the range from low to high includes it.
By their numbers in this assay, from the lowest: compounds 1, 2 and 4 (each within the scatter of the next, the first and the last beyond it); then compound 3.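

In this assay, putting 2-carboxy-1-fluoroethyl in place of 2-carboxypropyl on the aromatic carbon two atoms from the ring nitrogen gives a 3.6-fold lower number from compound 3 to compound 4 (0.56 log units; beyond the scatter) and counts as a modest step. Going by these compounds alone, this is the first single-place comparison, and it shows that the number responds to a change in the acid-bearing chain alone, with the rest of the structure held the same; the change here removes the branching methyl and puts a fluorine on the chain carbon that joins the ring, and the number comes down rather than going up. Nothing measured on these compounds says why the number moved.

As far as these compounds go, how the step divides between losing the methyl and gaining the fluorine stays open, and a chain carrying the fluorine together with the methyl, or the plain unbranched chain on this same ring, would help to separate the two. Also open, from the compounds shown here alone, is how a hydroxyl group or a second fluorine on that chain carbon, or a longer chain ending in the carboxylic acid, would move the number.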